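A few compounds are considered here, and "the series" means these few. Any claim that something is new, unique, unknown or untested is made for them only; others in the source may bear on it.

Measured so far in an ADME assay on HEK293 cells (Homo sapiens) for cytotoxicity, read by MTT assay, with a stated time of 72 h; on this read-out higher numbers stand for weaker inhibition and lower numbers for stronger inhibition:

- compound 1, `O=C(CN1CCN(C(=O)c2cccc(Cl)c2)CC1)N1CCN(CCCc2c[nH]c3ccccc23)CC1`: 99100 nM
- compound 2, `COc1cccc(C(=O)N2CCN(CC(=O)N3CCN(CCCc4c[nH]c5ccccc45)CC3)CC2)c1`: 143000 nM
- compound 3, `O=C(CN1CCN(C(=O)c2ccc(Cl)cc2)CC1)N1CCN(CCCc2c[nH]c3ccc(F)cc23)CC1`: 44500 nM

Compound 3 gives the lowest number of the three; the gaps to compound 1 and to compound 2 are both beyond the scatter. The difference between the core of compound 1 and the core of compound 3 is not broken down here.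

One change recurs in the set. From compound 1 to compound 2 it reads methoxy in place of chloro on an aromatic carbon and produced a 1.4-fold higher number from compound 1 to compound 2 (0.16 log units; within the scatter). Compound 4, `COc1ccc(C(=O)N2CCN(CC(=O)N3CCN(CCCc4c[nH]c5ccc(F)cc45)CC3)CC2)cc1`, is not yet measured in this assay; it stands to compound 3 as methoxy in place of chloro on an aromatic carbon. The two place descriptions differ in their wording: in the first pair the group sits meta to a large group, in the second para to a large group, so this is the same kind of change rather than the same change.

Within the data shown here, with only one measured instance, the expectation for compound 4 rests on compound 1 and compound 2, whose step a 1.4-fold higher number from compound 1 to compound 2 (0.16 log units; within the scatter) was within the scatter. The step from compound 3 to compound 4 in this assay is therefore estimated to be small as well, at a 1.3-fold higher number from compound 3 to compound 4 (0.13 log units; within the scatter). Compound 4 is expected to give about 60000 nM in this assay, with a likely range from 30000 nM to 120000 nM.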

Compound 4, half-maximal inhibitory concentration: 141000 nM
Estimate against measurement, compound 4: 2.4-fold (0.37 log units) below; measured number outside the range, above it.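

In this assay, methoxy in place of chloro on an aromatic carbon, here 4-chlorophenyl to 4-methoxyphenyl, gives a 3.2-fold higher number from compound 3 to compound 4 (0.50 log units; beyond the scatter), while the same kind of change on the core of compound 1 gives a 1.4-fold higher number from compound 1 to compound 2 (0.16 log units; within the scatter). Taken singly, only the newer step lies beyond the scatter, yet the two steps cannot be told apart: the same change on two cores in this assay, a 1.4-fold higher number (0.16 log units; within the scatter) from compound 1 to compound 2 and a 3.2-fold higher number (0.50 log units; beyond the scatter) from compound 3 to compound 4, 2.2-fold (0.34 log units) apart, within the scatter of two such steps. This is consistent with the change carrying over from one core to the other with a size inside the span of these two steps, but two pairs do not establish a transfer rule, and they do not show that the core alters the step, as the pairs differ both in the core and in where the group sits on the ring.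

Still open, going by these compounds, is whether the core or the place of the group has any bearing on the step, a question that needs chloro and methoxy compared at one place on each core. Also open, on these data alone, is how this read-out responds to other groups at that place, such as a nitrile, a trifluoromethyl, a carboxylic acid or an amine, or to a longer chain in place of methoxy.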